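From compound 1 to its nitro analogue, compound 4

The compounds below may be only part of what the source reports. "The series", "measured", "known", "first", "only" and "open" are said of these compounds alone.

Compound 1 `C/C(=C\c1ccccc1)C(=O)/C=C/c1ccccc1`: 33600 nM
Compound 2 `C/C(=C\c1ccccc1)C(=O)/C=C/c1ccc([N+](=O)[O-])cc1`: 43300 nM
Compound 3 `C/C(=C\c1ccccc1)C(=O)/C=C/c1ccc(N(C)C)cc1`: 53000 nM

These three values come from an ADME assay on LLC-MK2 cells (Macaca mulatta) for cytotoxicity, read by MTT assay, with a stated time of 48 h; a lower number here means that less compound is tolerated, a higher number that more compound is tolerated. Compound 1 is not set apart from the other two, as the measured steps show: a 1.3-fold higher number from compound 1 to compound 2 (0.11 log units; within the scatter), and a 1.6-fold higher number from compound 1 to compound 3 (0.20 log units; within the scatter). The remaining step, a 1.2-fold higher number from compound 2 to compound 3 (0.09 log units; within the scatter), does not separate the pair either.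

Compound 4 `C/C(=C\c1ccc([N+](=O)[O-])cc1)C(=O)/C=C/c1ccccc1` has not yet been measured. It has nitro in place of hydrogen on an aromatic carbon of compound 1, para to a large group: nitro in place of hydrogen on an aromatic carbon. Within the data shown here, the closest precedent is compound 2, which carries a nitro group elsewhere in the same core, with the step of a 1.3-fold higher number from compound 1 to compound 2 (0.11 log units; within the scatter). The step of a 1.6-fold higher number from compound 1 to compound 3 (0.20 log units; within the scatter) involves a different group but likewise stays small. No step beyond the scatter is therefore expected for the new compound, and no direction can be called.

The estimated change is a 1.2-fold higher number from compound 1 to compound 4 (0.08 log units; within the scatter). For compound 4 the expected value is 40000 nM, with an estimated range of 22000 nM to 70000 nM.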

Compound 4, half-maximal cytotoxic concentration: 264000 nM
Estimate against measurement, compound 4: 6.6-fold (0.82 log units) below, and the stated range ends below it.
By their numbers in this assay, from the lowest: compounds 1, 2 and 3 (each within the scatter of the next); then compound 4.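

In this assay, among these compounds, the step of a 7.9-fold higher number from compound 1 to compound 4 (0.90 log units; beyond the scatter) is the first to reach beyond the scatter, and it comes from nitro in place of hydrogen on an aromatic carbon, para to a large group. The same exchange at the place it occupies in compound 2 gives only a 1.3-fold higher number from compound 1 to compound 2 (0.11 log units; within the scatter) and stays within the scatter, so among these compounds the outcome of adding nitro to the core of compound 1 depends on where the group stands. Nothing measured here accounts for this difference between the two places.

From the compounds shown here alone, whether a methoxy group or a carboxylic acid at this place would move the number as far remains open, as does whether dimethylamino, seen so far only at its place in compound 3, would do so here. Also open, going by these compounds, is what nitro groups at both places together would give.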